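Cyanophenyl for cyclopentenyl on the aminoalkyl amide of compound 3

The source may hold more compounds than are shown below. What is called first, only, known or untested is meant among the compounds shown, and "the series" means these compounds.

Compounds 1 and 2 share the core and differ only in the chain on the amine nitrogen; compound 1 is `CC(C)CCNCCN(C(=O)[C@@H]1C[C@H]1c1ccccc1)c1ccc(-c2ccccc2)cc1` and compound 2 is `CCC(C)CNCCN(C(=O)[C@@H]1C[C@H]1c1ccccc1)c1ccc(-c2ccccc2)cc1`. Among the compounds with values here, in a functional assay for agonist activity at G protein-coupled receptor 88 (Homo sapiens), read by HTRF and cAMP accumulation (a higher number here means that more compound is needed for the effect, a lower number that less compound is needed), compound 1 gives 5.1 nM, and compound 2 gives 4.7 nM; the only step measured within one place, a 1.1-fold lower number from compound 1 to compound 2 (0.04 log units; within the scatter), is within the scatter and concerns a part of the molecule far from the change considered here. Compound 3, `CC(C)C[C@H](N)CN(C(=O)[C@@H]1C[C@H]1c1ccccc1)c1ccc(C2=CCCC2)cc1`, carries a branched amino chain and a cyclopentenyl group on the core; in this assay compound 3 gives 1200 nM, the highest of the three numbers shown, beyond the scatter from both compound 1 and compound 2.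

Compound 4 is `CC(C)C[C@H](N)CN(C(=O)[C@@H]1C[C@H]1c1ccccc1)c1ccc(-c2cccc(C#N)c2)cc1`. It differs from compound 3 in one place: 3-cyanophenyl in place of cyclopent-1-en-1-yl on an aromatic carbon. Within the data shown here, no measured pair isolates this position, and compounds 1 and 2 differ from compound 3 in more than one place, so they give only a loose pointer that an aromatic group on the core goes with lower numbers. The step of a 10-fold lower number from compound 3 to compound 4 (1.00 log units; beyond the scatter) is therefore expected to be a lower number, with wide uncertainty. Compound 4 is estimated at 120 nM, in the range 15 nM to 900 nM.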

Compound 4, half-maximal effective concentration: 4500 nM
For compound 4 the middle estimate is 38-fold (1.57 log units) below the measured one, and the stated range ends below it.
By their numbers in this assay, from the lowest: compounds 2 and 1 (each within the scatter of the next); then compound 3; then compound 4.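

Notes on the position para to a large group: in this assay, 3-cyanophenyl in place of cyclopent-1-en-1-yl gives a 3.8-fold higher number from compound 3 to compound 4 (0.57 log units; beyond the scatter), a modest step but the first direct reading at this place, and it shows that the group held here affects the number even when the number is already high. With the branched amino chain kept fixed, the six-membered aromatic ring bearing a nitrile does not lower the number, so the loose link between an aromatic group here and lower numbers does not hold for this pair. No available evidence bears on the origin of this step.

Within the data shown here, the single pair changes ring type, group size and the nitrile together, so it remains open which of these carries the step; a methoxy group or a chlorine atom in place of the nitrile on the same ring would help to separate them. Also open, as far as these compounds go, is whether the same exchange would give a step of similar direction and size on the amine chains of compound 1 and compound 2.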